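The source may hold more compounds than are shown below. What is called first, only, known or untested is meant among the compounds shown, and "the series" means these compounds.

Working notes on the series. Within the data shown here, compound 3 `Cc1nsc2c1ncn2[C@@H]1O[C@H](CO)[C@@H](O)[C@H]1O` is the only member that gives a number in a functional assay on L1210 cells (Mus musculus) for antiproliferative activity; a lower number here means a stronger inhibitor, a higher number a weaker inhibitor: compound 3 gives 10000 nM. Compound 1 `CSc1nc2c(C)nsc2n1[C@H]1C[C@H](O)[C@@H](CO)O1` gives only a limit, compound 1 at > 100000 nM in this assay. Compound 2 `CSc1nc2c(C)nsc2n1[C@@H]1O[C@H](CO)[C@@H](O)[C@@H]1O` likewise gives only a limit, compound 2 at > 100000 nM in this assay. So compound 3 stands as the sole numbered point, with the two other values sitting at the limit (the limit of > 100000 nM in this assay, at which 2 of the 3 values shown sit).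

Among the measured compounds shown here, the one measured step, hydroxy in place of hydrogen on a saturated ring carbon, is a step that the two limits leave unreadable from compound 1 to compound 2, and it cannot be read in size.

Compound 4 `CSc1nc2c(C)nsc2n1[C@@H]1O[C@H](CO)[C@@H](O)[C@H]1O` is not yet measured in this assay. Relative to compound 3 the change is methylsulfanyl in place of hydrogen on an aromatic carbon. For the measured compounds named here, no measured step carries this change, so there is no direct reading of its size. What the series does show is that compound 1 and compound 2 both bear the methylsulfanyl group and both sit at the limit (the limit of > 100000 nM in this assay, at which 2 of the 3 values shown sit), while compound 3, without it, gives a number; compound 3 is the only case going the other way.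

On that footing compound 4 is expected to be weaker than compound 3 in this assay, an estimated step of a 5.0-fold higher number from compound 3 to compound 4 (0.70 log units; beyond the scatter). The estimate for compound 4 is 50000 nM, with a range from 10000 nM to 200000 nM.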

Compound 4, half-maximal inhibitory concentration: > 100000 nM
Compound 4 was reported as a limit; the forecaster's own chance of this, stated with the estimate: 50%; at least 2.0-fold (0.30 log units) between middle value and limit.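

Compound 4 gives the series its first readable step for this change: in this assay, methylsulfanyl in place of hydrogen on an aromatic carbon of the five-membered aromatic ring with 2 nitrogen brings an at least 10-fold higher number from compound 3 to compound 4 (1.00 log units; beyond the scatter), and the true size may be larger since one end is a limit. Every compound shown that bears methylsulfanyl now sits at one limit, and compound 3, with hydrogen at this carbon, is the only one with a number: the limit of > 100000 nM in this assay, at which 3 of the 4 values shown sit. The steps from compound 1 and from compound 2 to compound 4 cannot be read, so with methylsulfanyl in place neither the hydroxy change nor the change of drawn configuration shows a size: the fact that compounds 2 and 4 differ only in the configuration as drawn.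

From the compounds shown here alone, only hydrogen and methylsulfanyl appear at this aromatic carbon, so it stays open whether an amine, a methoxy group or a longer chain such as ethylsulfanyl would keep a number in this assay or also reach the limit. Also open, going by these compounds, is how the hydroxy change and the configuration change act with hydrogen at this carbon, where a number could be read.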